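Phenyl for 4-(tert-butyl)phenoxy: Expected Permeability of Compound 4

The source may hold more compounds than are shown below. What is called first, only, known or untested is meant among the compounds shown, and "the series" means these compounds.

Compound 1 `CC(C)(C)c1ccc(Oc2ccc3c(NCCCNCc4ccco4)ccnc3c2)cc1`: 317 10^-6 cm/s
Compound 2 `COc1ccc(F)cc1CNCCCNc1ccnc2cc(Cc3ccccc3)ccc12`: 23 10^-6 cm/s
Compound 3 `COc1ccc(F)cc1CNCCCNc1ccnc2cc(Oc3ccc(C(C)(C)C)cc3)ccc12`: 317 10^-6 cm/s

All three were run in an ADME assay for permeability, using PAMPA, with a stated time of 30 min, at pH 7.4; a lower number here means that the compound crosses the layer more slowly, a higher number that the compound crosses the layer faster. Compound 3 stands at the top of this small set: no change at the digits printed from compound 1 to compound 3 (within the scatter), while a 14-fold higher number from compound 2 to compound 3 (1.14 log units; beyond the scatter).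

Compound 4 `COc1ccc(F)cc1CNCCCNc1ccnc2cc(-c3ccccc3)ccc12` differs from compound 3 by phenyl in place of 4-(tert-butyl)phenoxy on an aromatic carbon. Within the data shown here, only one measured step bears on this: a 14-fold higher number from compound 2 to compound 3 (1.14 log units; beyond the scatter), where benzyl, a small carbon-only group, gave way to the same 4-(tert-butyl)phenoxy that now leaves. Phenyl resembles benzyl far more than it resembles 4-(tert-butyl)phenoxy, so a move back down in this assay is expected, probably most of the way. Compound 4 is therefore estimated at 40 10^-6 cm/s (range 15 10^-6 cm/s to 120 10^-6 cm/s), a step of a 7.9-fold lower number from compound 3 to compound 4 (0.90 log units; beyond the scatter).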

Compound 4, apparent permeability: 237 10^-6 cm/s
Compound 4: the middle estimate sits 5.9-fold (0.77 log units) below what was measured; measured number above the stated range.
By their numbers in this assay, from the lowest: compound 2; then compounds 4, 1 and 3 (each within the scatter of the next).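

In this assay the large 4-(tert-butyl)phenoxy group proves unnecessary at this position: phenyl, with fewer heavy atoms and no hydrogen-bond acceptor, stays level with it (a 1.3-fold lower number from compound 3 to compound 4 (0.13 log units; within the scatter)). Among the three groups compared here, benzyl alone gives the low number, and phenyl in its place makes a large difference (a 10-fold higher number from compound 2 to compound 4 (1.01 log units; beyond the scatter)). No measured evidence here explains this contrast. Still open, on these data alone, is whether phenoxy or a pyridine ring at this position would match phenyl or benzyl. Phenyl's behaviour with the furan-2-yl side chain of compound 1 also remains open.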